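This account rests on a few compounds, and the source may have more. Where it says the series, first, only, none or still open, it means among the compounds named here.

Two measured compounds share one core: compound 1, `CC(C#CCn1ccnc1)N1CCCC1=O`, and compound 2, `Cc1cncn1CC#CC(C)N1CCCC1=O`, which differs from it by methyl in place of hydrogen on an aromatic carbon. In a functional assay on the whole organism for antagonist activity, with Mus musculus as the target (a lower number here means that less compound is needed, a higher number that more compound is needed for the effect), compound 1 gives 45 mg/kg, and compound 2 gives 25.4 mg/kg, so the step of a 1.8-fold lower number from compound 1 to compound 2 (0.25 log units; within the scatter) is a small one. Compound 3, `O=C1NCCN1CC#CCn1ccnc1`, is built on a different core; how the two cores differ is not broken down here. For compound 3 this assay reports only a limit, > 100 mg/kg. Compound 4, `Cc1cncn1CC#CCN1CCNC1=O`, has not been measured yet and differs from compound 3 by methyl in place of hydrogen on an aromatic carbon, the same change that turns compound 1 into compound 2. The step expected here is a number no higher from compound 3 to compound 4 (the limit leaves the size open), since the like step a 1.8-fold lower number from compound 1 to compound 2 (0.25 log units; within the scatter) stayed within the usual scatter. Because compound 3 sits at the limit of > 100 mg/kg in this assay, at which 1 of the 3 values shown sits, compound 4 may well again yield only a limit rather than a number. Compound 4 is expected to come out near 100 mg/kg, between 40 mg/kg and 300 mg/kg.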

Compound 4, dose for half-maximal effect: > 100 mg/kg
Compound 4: a limit, no number; the forecaster's own chance of this, stated with the estimate: 65%; the middle value lies on the limit itself.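

In this assay compound 4 gives > 100 mg/kg, which is a limit and not a number. Compound 3 also stands at a limit, so no step can be read between compound 3 and compound 4: the limit of > 100 mg/kg in this assay, at which 2 of the 4 values shown sit. The compounds shown leave open whether methyl in place of hydrogen on an aromatic carbon changes the result on this core.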